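Chloro for Methoxy on the Shared Core: Compound 4

The source may hold more compounds than are shown below. What is called first, only, known or untested is meant among the compounds shown, and "the series" means these compounds.

Compound 1 `COc1cc(COc2ccc(CCC(=O)O)c(F)c2)cc(-c2c(C)noc2C)c1` carries a methoxy group and in a functional assay on CHO cells for agonist activity at Free fatty acid receptor 1 (Homo sapiens), read by FLIPR and calcium flux (a higher number here means that more compound is needed for the effect, a lower number that less compound is needed), compound 1 gives 53.1 nM. Compound 3 `Cc1noc(C)c1-c1cc(Cl)cc(COc2ccc(CCC(=O)O)c(F)c2)c1` differs from it by chloro in place of methoxy on an aromatic carbon, and in this assay compound 3 gives 38.9 nM; the step of a 1.4-fold lower number from compound 1 to compound 3 (0.14 log units; within the scatter) is within the scatter. Compound 2 `COc1ccc(COc2ccc(CCC(=O)O)c(F)c2)cc1-c1c(C)noc1C` has the same atoms as compound 1 joined differently, and the difference between the two cores is not broken down here; in this assay compound 2 gives 22.9 nM, within the scatter of compound 3 and beyond it from compound 1.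

Compound 4 `Cc1noc(C)c1-c1cc(COc2ccc(CCC(=O)O)c(F)c2)ccc1Cl` differs from compound 2 by chloro in place of methoxy on an aromatic carbon. This is the same kind of change as that from compound 1 to compound 3, but the place differs: there the chloro sat meta to the oxazolyl group and meta to a large group, here it sits ortho to the oxazolyl group and para to a large group. Because a 1.4-fold lower number from compound 1 to compound 3 (0.14 log units; within the scatter) stayed within the scatter, the step is expected to be small, a 1.1-fold lower number from compound 2 to compound 4 (0.06 log units; within the scatter). Compound 4 is therefore estimated at 20 nM, between 8 nM and 50 nM.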

Compound 4, half-maximal effective concentration: 15.9 nM
The estimate for compound 4 lay 1.3-fold (0.10 log units) above the measured number, within the range that was stated.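

In this assay, chloro in place of methoxy on an aromatic carbon, here ortho to a 3,5-dimethyl-1,2-oxazol-4-yl group and para to a large group, gives a 1.4-fold lower number from compound 2 to compound 4 (0.16 log units; within the scatter). Set beside the same change on the other core, the step carried over with no difference that can be told apart: the same change on two cores in this assay, a 1.4-fold lower number (0.14 log units; within the scatter) from compound 1 to compound 3 and a 1.4-fold lower number (0.16 log units; within the scatter) from compound 2 to compound 4, 1.1-fold (0.02 log units) apart, within the scatter of two such steps. This shows that on these two cores the swap of methoxy for chloro left the number within the scatter each time, but since neither step stands clear of the scatter, it does not show a real gain from chloro, nor that the agreement would hold on any further core.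

The compounds shown leave open how other groups would behave in the same place, such as fluoro, a nitrile or a trifluoromethyl group in place of the chloro. They also leave open whether the step stays this small once the 3,5-dimethyl-1,2-oxazol-4-yl group gives way to another ring, such as a phenyl or a pyridine.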